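One methoxy fewer: a repeated change in two cores

This account rests on a few compounds, and the source may have more. Where it says the series, first, only, none or still open, it means among the compounds named here.

In a functional assay on M14 cells (Homo sapiens) for cytotoxicity, read by sulforhodamine B assay, with a stated time of 48 h, tested at 10 uM (on this read-out lower numbers stand for a stronger effect and higher numbers for a weaker effect at the one concentration tested), compound 1 `COc1cc(-c2cc(/C=C/C(=O)c3ccc(N)cc3)[nH]n2)cc(OC)c1OC` gives -64%, and compound 2 `COc1ccc(-c2cc(/C=C/C(=O)c3ccc(N)cc3)[nH]n2)cc1OC` gives -42%. The two differ by a single change, (hydrogen in place of methoxy on an aromatic carbon), which moved the read-out a number 22 percentage points higher from compound 1 to compound 2 (beyond the scatter). Compound 3 `COc1cc(C(=O)/C=C/c2cc(-c3cc(OC)c(OC)c(OC)c3)n[nH]2)cc(OC)c1OC` stands on a different core; how that core differs from the core of compound 1 is not broken down here. In this assay compound 3 gives -90%, the lowest of the three numbers. Compound 4 `COc1ccc(-c2cc(/C=C/C(=O)c3cc(OC)c(OC)c(OC)c3)[nH]n2)cc1OC` has not yet been measured. It arises from compound 3 by hydrogen in place of methoxy on an aromatic carbon, the same change as that from compound 1 to compound 2, at a place described in the same words. Among the compounds shown this change occurs twice in all, so the one measured instance is the only guide available. Since that instance weakened the effect, a step of similar size is expected in the other core. The step from compound 3 to compound 4 in this assay is estimated at a number 22 percentage points higher from compound 3 to compound 4 (beyond the scatter), resting on the earlier step of a number 22 percentage points higher from compound 1 to compound 2 (beyond the scatter). Compound 4 is therefore expected to give about -68%, most likely between -85% and -45%.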

Compound 4, a percentage reported as activity, at one concentration (the size of the read-out at that concentration, not a potency): -70%
Estimate against measurement, compound 4: 2 percentage points above, and the stated range covers the measured number.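

In this assay, the same loss of a methoxy on the second core again weakened the effect, giving a number 20 percentage points higher from compound 3 to compound 4 (beyond the scatter). Set side by side, the two steps point the same way and are no further apart than repeat measurements would be expected to scatter: the same change on two cores in this assay, a number 22 percentage points higher (beyond the scatter) from compound 1 to compound 2 and a number 20 percentage points higher (beyond the scatter) from compound 3 to compound 4, 2 percentage points apart, within the scatter of two such steps. So in these two pairs the change carried over from the core of compound 1 to the core of compound 3 at about the same size, but two pairs are a small sample, and they show neither why the methoxy matters nor how the change would behave on any further core.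

The compounds shown leave open what happens when this methoxy gives way to something other than hydrogen, such as a hydroxyl, a fluorine or an ethoxy. Also open, going by these compounds, is whether taking a further methoxy from the same ring would bring another step of this kind.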